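The source may hold more compounds than are shown below. What is called first, only, known or untested is meant among the compounds shown, and "the series" means these compounds.

In a functional assay on Caco-2 cells (Homo sapiens) for cytotoxicity, read by MTT assay, with a stated time of 48 h (a higher number here means a weaker inhibitor, a lower number a stronger inhibitor), compound 1 (`C[n+]1cccc(OP(=O)([O-])OC[C@H]2O[C@@H](n3cc(F)c(=O)[nH]c3=O)C[C@@H]2OC(=O)c2ccccc2)c1`) gives 1380 nM, and compound 2 (`CCOC(=O)C[n+]1cccc(OP(=O)([O-])OC[C@H]2O[C@@H](n3cc(F)c(=O)[nH]c3=O)C[C@@H]2OC(=O)c2ccccc2)c1`) gives 2620 nM. Going by the values given here, compound 2 therefore stands within the scatter of the only other measured compound, and neither can be placed ahead of the other. The step between them is a 1.9-fold higher number from compound 1 to compound 2 (0.28 log units; within the scatter), with ethoxycarbonyl in place of hydrogen on a saturated chain carbon bound to an aromatic nitrogen. Compound 3 (`C[N+]1(C)CCC(OP(=O)([O-])OC[C@H]2O[C@@H](n3cc(F)c(=O)[nH]c3=O)C[C@@H]2OC(=O)c2ccccc2)CC1`) differs from compound 2 in a larger way: a group of 8 heavy atoms (7 carbon, 1 nitrogen; one six-membered non-aromatic ring with 1 hetero atom) in place of a group of 12 heavy atoms (9 carbon, 1 nitrogen, 2 oxygen; one six-membered aromatic ring with 1 hetero atom), on an oxygen. Among the compounds with values here, the one measured step keeps the six-membered aromatic ring in place, so it bears on this exchange only indirectly. Within the data shown here, with a 1.9-fold higher number from compound 1 to compound 2 (0.28 log units; within the scatter) as the sole guide, no step beyond the scatter is expected in this assay, although the uncertainty is wide. The estimated step is a 1.3-fold lower number from compound 2 to compound 3 (0.12 log units; within the scatter). For compound 3 the expected value is 2000 nM, with an estimated range from 700 nM to 6000 nM.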

Compound 3, half-maximal inhibitory concentration: 15700 nM
The estimate for compound 3 lay 7.9-fold (0.89 log units) below the measured number; measured number above the stated range.
By their numbers in this assay, from the lowest: compounds 1 and 2 (each within the scatter of the next); then compound 3.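

In this assay, the group on the oxygen whose other neighbours are phosphorus proves to matter in a way the earlier pair could not show: the six-membered non-aromatic ring with 1 hetero atom in place of the six-membered aromatic ring with 1 hetero atom gives an 11-fold higher number from compound 1 to compound 3 (1.06 log units; beyond the scatter), and in place of the larger aromatic group it gives a 6.0-fold higher number from compound 2 to compound 3 (0.78 log units; beyond the scatter). Both steps lie beyond the scatter, whereas the ethoxycarbonyl change on the saturated chain carbon stayed within it, and the net charge of +1 is the same for the groups that leave and enter. Nothing at hand gives a reason for this rise in the number.

From the compounds shown here alone, the non-aromatic ring appears in compound 3 alone, so it remains open whether the ring itself or the groups on its nitrogen carry the step. Also open, going by these compounds, is how an open-chain ammonium group on this oxygen, or a carboxylic acid on the chain of the aromatic ring's nitrogen, would read here.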